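This account rests on a few compounds, and the source may have more. Where it says the series, first, only, none or still open, it means among the compounds named here.

Three compounds share one core so far: compound 1 `OC[C@H]1O[C@@H](n2cnc3c(NCc4ccccc4F)ncnc32)[C@H](O)[C@@H]1O`, compound 2 `OC[C@H]1O[C@@H](n2cnc3c(NCc4cccc(F)c4)ncnc32)[C@H](O)[C@@H]1O` and compound 3 `COc1cccc(CNc2ncnc3c2ncn3[C@@H]2O[C@H](CO)[C@@H](O)[C@H]2O)c1OC`. In a functional assay on B16 cells (Mus musculus) for antiproliferative activity, with a stated time of 72 h (a higher number here means a weaker inhibitor, a lower number a stronger inhibitor), compound 1 gives > 166000 nM, and this is a limit, not a number. In this assay compound 2 has the entry "not determined" (no result reported). In this assay compound 3 has the entry "not determined" (no result reported), so it has no place on the scale and gives no starting value for the next step.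

Compound 4 `OC[C@H]1O[C@@H](n2cnc3c(NCc4ccc(F)c(Cl)c4)ncnc32)[C@H](O)[C@@H]1O` comes from 3-chloro-4-fluorophenyl in place of 2,3-dimethoxyphenyl on a saturated chain carbon bound to a nitrogen on an aromatic ring, with 3-chloro-4-fluorophenyl in place of 2,3-dimethoxyphenyl on a saturated chain carbon bound to a nitrogen on an aromatic ring. Within the data shown here, no measured pair gives a size for such a change. Among the measured compounds shown here, the only guide is compound 1 with > 166000 nM. Compound 4 is therefore expected to stay weak in this assay, with at most a small move towards stronger inhibition, and a reported limit is quite possible. The estimate for compound 4 is 120000 nM, with an expected range of 20000 nM to 300000 nM.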

Compound 4, half-maximal inhibitory concentration: 167000 nM
Beside the measured number, compound 4's estimate is 1.4-fold (0.14 log units) below it; the range from low to high includes it.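

No new step can be read between compound 1 and compound 4, because compound 1 carries a limit and not a number: the limit of > 166000 nM in this assay, at which 1 of the 4 values shown sits.

The compounds shown leave open how far any change of the group on the saturated chain carbon moves the result in this assay.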